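This account rests on a few compounds, and the source may have more. Where it says the series, first, only, none or still open, it means among the compounds named here.

In a functional assay on U-251 cells (Homo sapiens) for inhibition, read by sulforhodamine B assay, with a stated time of 48 h (on this read-out lower numbers stand for stronger inhibition of growth and higher numbers for weaker inhibition of growth), compound 1 `Nc1cc(N)c2nc(-c3ccccc3)c(Oc3ccc(Cl)c(Cl)c3)nc2c1` gives 31600 nM. Compound 2 `Nc1cc(N)c2nc(-c3ccccc3)c(Sc3ccc(Cl)c(Cl)c3)nc2c1` carries a (3,4-dichlorophenyl)sulfanyl in place of the 3,4-dichlorophenoxy of compound 1. For compound 2 this assay reports only a limit, < 100000 nM, so the step that the limit leaves unreadable from compound 1 to compound 2 cannot be read (the limit of < 100000 nM in this assay, at which 1 of the 2 values shown sits). Compound 3 `Nc1cc(N)c2nc(-c3ccccc3)c(Sc3ccc(F)cc3)nc2c1` differs from compound 2 by 4-fluorophenyl in place of 3,4-dichlorophenyl on a sulfur. Among the measured compounds shown here, none of the measured steps touches this part of the molecule; the only measured step concerns the oxygen-to-sulfur exchange, which is itself unreadable. Compound 2 therefore stands only as a limit, and no shown step tells how large the step from compound 2 to compound 3 should be, nor its direction. Compound 3 is thus expected to lie near the same region, with the step that the limit leaves unreadable from compound 2 to compound 3 estimated as none beyond the scatter. For compound 3 the estimate in this assay is 40000 nM, within 8000 nM to 100000 nM.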

Compound 3, concentration for total growth inhibition: 31600 nM
Compound 3: the middle estimate sits 1.3-fold (0.10 log units) above what was measured; low and high end bracket the measured number.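

In this assay the series now holds one readable step at this position: no change at the digits printed from compound 1 to compound 3 (within the scatter), with (4-fluorophenyl)sulfanyl in place of 3,4-dichlorophenoxy on an aromatic carbon. This shows that this exchange, which alters both the linking atom and the halogens on the ring, does not move the read-out beyond the scatter. The steps that involve compound 2 still cannot be read, because compound 2 stands only as a limit: the limit of < 100000 nM in this assay, at which 1 of the 3 values shown sits.

The compounds shown leave open how the change of linking atom and the change of ring substituents would each read alone, as the two appear here only together. They also leave open how a morpholine, a carboxylic acid or a longer alkyl chain would read in place of the 4-fluorophenyl on the sulfur.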